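This account rests on a few compounds, and the source may have more. Where it says the series, first, only, none or still open, it means among the compounds named here.

Working notes on the series. The compounds share one core and differ only in the group attached to the amide-type nitrogen. Compound 1 `COc1cc2c(cc1OC)C(=O)C(CC1CCN(C(=S)Nc3ccccc3)CC1)C2` carries hydrogen on the aromatic carbon where compound 3 `COc1cc2c(cc1OC)C(=O)C(CC1CCN(C(=S)Nc3ccccc3Cl)CC1)C2` carries chloro; compound 2 `COc1cc2c(cc1OC)C(=O)C(CC1CCN(C(=S)Nc3cccc([N+](=O)[O-])c3)CC1)C2` is a further member of the set. In a functional assay on the whole organism (strain Swiss albino) with Mus musculus as the target, with a stated time of 0.5 h (on this read-out higher numbers stand for an effect only at larger amounts of compound and lower numbers for an effect already at smaller amounts), compound 1 gives 100 mg/kg and compound 3 gives 300 mg/kg, while compound 2 gives "not determined" (no result reported), so no number is reported for it. Within the data shown here, the single step available is a 3.0-fold higher number from compound 1 to compound 3 (0.48 log units; beyond the scatter). On the two numbers at hand compound 3 thus stands highest, with compound 1 nearest to it.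

Compound 4 `CCCCNC(=S)N1CCC(CC2Cc3cc(OC)c(OC)cc3C2=O)CC1` is the next entry. Relative to compound 3 the change is butyl in place of 2-chlorophenyl on an amide-type nitrogen. Among the measured compounds shown here, no measured step covers an exchange of this kind: the only step, a 3.0-fold higher number from compound 1 to compound 3 (0.48 log units; beyond the scatter), concerns chloro in place of hydrogen on an aromatic carbon and is of modest size. Replacing the whole 2-chlorophenyl removes the group that came with the higher number, yet nothing in the data tells how butyl behaves in its place. The estimate for compound 4 is accordingly a number close to those of the two measured compounds, with a step of a 1.5-fold lower number from compound 3 to compound 4 (0.18 log units; within the scatter) expected, within or near the scatter. Compound 4 is expected to give 200 mg/kg in this assay, in a range from 70 mg/kg to 600 mg/kg.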

Compound 4, minimum effective dose: 100 mg/kg
Compound 4: the middle estimate sits 2.0-fold (0.30 log units) above what was measured; low and high end bracket the measured number.
By their numbers in this assay, from the lowest: compounds 1 and 4 (each within the scatter of the next); then compound 3.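

Butyl in place of phenyl on the amide-type nitrogen gives no change at the digits printed from compound 1 to compound 4 (within the scatter) in this assay here, so among these compounds an aromatic ring at this place is not needed to reach the number of compound 1. Butyl in place of 2-chlorophenyl at the same place gives a 3.0-fold lower number from compound 3 to compound 4 (0.48 log units; beyond the scatter) on this read-out, which leaves compound 3 alone with the higher number and places the butyl chain with phenyl, not with 2-chlorophenyl. No measurement in hand speaks to the reason for either step.

Among these compounds, the steps to and from compound 2 cannot be read, so the nitro-bearing ring says nothing yet about this position, and the effect of chloro rests on the single pair of compound 1 and compound 3. From the compounds shown here alone, it remains open how a longer chain such as octyl, a branched chain such as tert-butyl, a benzyl group, or a butyl chain ending in a carboxylic acid or an amine would read on the same nitrogen, and whether the match between butyl and phenyl would hold for any of them.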